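A few compounds are considered here, and "the series" means these few. Any claim that something is new, unique, unknown or untested is made for them only; others in the source may bear on it.

Measured so far in a functional assay on A2780/DX3 cells (Homo sapiens) for antiproliferative activity, read by MTT assay, with a stated time of 3 days; on this read-out lower numbers stand for stronger inhibition and higher numbers for weaker inhibition:
compound 1, `CC/C=C\COC1(c2ccc(Cl)cc2)SC=C(C)n2c1noc2=O`, with 103000 nM
compound 2, `CC1=CSC(O)(c2cccc([N+](=O)[O-])c2)c2noc(=O)n21`, with 129000 nM
compound 3, `CCCCCCCCCCCCCCCCCCOC1(c2ccc(Cl)cc2)SC=C(C)n2c1noc2=O`, with > 100000 nM

The value of compound 3 is a limit of this assay rather than a number, (the limit of > 100000 nM in this assay, at which 1 of the 3 values shown sits). Compound 1 stands alongside compound 2, the two values lying within the usual scatter of each other, so neither can be set apart from the other on these readings. Compound 1 is the starting point for the step followed here.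

The compound not yet measured is compound 4, `CCCCOC1(c2ccc(Cl)cc2)SC=C(C)n2c1noc2=O`. It differs from compound 1 in one place: propyl in place of but-1-en-1-yl on a saturated chain carbon bound to an oxygen on a saturated carbon. The chain bound to the oxygen becomes shorter by one carbon and loses its double bond outside aromatic rings. Going by the values given here, no measured pair shows a change of this kind, so nothing in the data points to a direction. In this assay the expectation for compound 4 is a value close to that of compound 1, with no change beyond the scatter: an estimated 100000 nM, with a range from 40000 nM to 250000 nM. The estimated step of a 1.0-fold lower number from compound 1 to compound 4 (0.01 log units; within the scatter) is expected to be small.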

Compound 4, half-maximal inhibitory concentration: 49000 nM
Compound 4: the middle estimate sits 2.0-fold (0.31 log units) above what was measured; the measured number falls inside the stated range.
By their numbers in this assay, from the lowest: compound 4; then compounds 1 and 2 (each within the scatter of the next).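

Going by these compounds alone, compound 4 gives the first readable step at the chain on the oxygen: in this assay, butoxy in place of (pent-2-en-1-yl)oxy gives a modest gain in inhibition (a 2.1-fold lower number from compound 1 to compound 4 (0.32 log units; beyond the scatter)). The earlier compounds shown here offered no such step, so this shows that the chain on the oxygen can shift the read-out, although the shorter chain and the loss of the double bond arrive together in this single change. Nothing measured here accounts for the step.

Still open, going by these compounds, is whether the gain follows the shorter length or the missing double bond, which a saturated chain the same length as pent-2-en-1-yl, namely pentyl, would help to separate. Also open, on these data alone, is how a shorter ethyl chain, or an amine or a carboxylic acid at the end of the chain, would read.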